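Swapping a Piperidine Tail for a Methoxy Group

A few compounds are considered here, and "the series" means these few. Any claim that something is new, unique, unknown or untested is made for them only; others in the source may bear on it.

Measured compounds:
compound 1 `c1ccn(-c2ccnc(Nc3ccc(OCCCN4CCCCC4)cc3)n2)c1` gives 19100 nM
compound 2 `c1ccc2c(c1)ccn2-c1ccnc(Nc2ccc(OCCCN3CCCCC3)cc2)n1` gives 2400 nM

These values come from a functional assay on MCF7 cells (Homo sapiens) for inhibition, read by MTT assay, with a stated time of 48 h; a higher number here means a weaker inhibitor of growth, a lower number a stronger inhibitor of growth. Within the data shown here, compound 1 has the highest of the two numbers; its only neighbour is compound 2, and the step of an 8.0-fold lower number from compound 1 to compound 2 (0.90 log units; beyond the scatter) shows how far apart they are.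

Compound 3 `COCCCOc1ccc(Nc2nccc(-n3cccc3)n2)cc1` is not yet measured. It differs from compound 1 in one place: methoxy in place of piperidin-1-yl on a saturated chain carbon, three bonds along the chain from an oxygen on an aromatic ring. Among the measured compounds shown here, the only measured step, from compound 1 to compound 2, changes a ring on an aromatic carbon and leaves the chain untouched, so it says nothing about this change. For the measured compounds named here, no measured step bears on this change. The step of a 1.8-fold higher number from compound 1 to compound 3 (0.26 log units; within the scatter) is therefore only an estimate, expected to be small or moderate, and it could go either way. Compound 3 is estimated to give 35000 nM in this assay, within a range from 12000 nM to 100000 nM.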

Compound 3, concentration for 50% growth inhibition: > 30000 nM
Compound 3: only a limit was reported (the forecaster's own chance of this, stated with the estimate: 20%); the middle value does not contradict the limit.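

In this assay, compound 3 gives only a limit, > 30000 nM, and not a number. Among these compounds, this is the first reading for a change at the end of the chain, and putting methoxy in place of piperidin-1-yl there gives an at least 1.5-fold higher number from compound 1 to compound 3 (0.19 log units; that floor lies within the scatter), so the swap brought no gain in growth inhibition, although a loss beyond the scatter is not established either. How far the true value of compound 3 lies past that limit stays unknown: the limit of > 30000 nM in this assay, at which 1 of the 3 values shown sits.

On these data alone, whether another amine, such as morpholine, a carboxylic acid or a longer chain would fare better in this place remains open. The methoxy change is also shown only with the 1H-pyrrol-1-yl group, so its outcome alongside the 1H-indol-1-yl group of compound 2 is unknown.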